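Methylating the oxime oxygen of compound 2

The source may hold more compounds than are shown below. What is called first, only, known or untested is meant among the compounds shown, and "the series" means these compounds.

Compound 2 `O/N=C(\CCCN1CCN(c2ccccn2)CC1)c1ccc(F)cc1` stands second highest of the three numbers in a functional assay on HEK293 cells with D(4) dopamine receptor (Homo sapiens) as the target, read by FLIPR (a higher number here means that more compound is needed for the effect, a lower number that less compound is needed), where compound 2 gives 9.5 nM. Compound 1 `O/N=C(\CCN1CCN(c2ccccn2)CC1)c1ccc(F)cc1F` gives 8.9 nM in this assay, within the scatter of compound 2. Compound 3 `O/N=C(/CCCN1CCN(c2ccccn2)CC1)c1ccc(F)cc1` gives 59.3 nM in this assay; the step of a 6.2-fold higher number from compound 2 to compound 3 (0.80 log units; beyond the scatter) rests on the fact that compounds 2 and 3 differ only in the configuration as drawn alone. Compound 4 `CO/N=C(\CCCN1CCN(c2ccccn2)CC1)c1ccc(F)cc1` differs from compound 2 by methyl in place of hydrogen on an oxygen. Among the measured compounds shown here, no measured step alters a substituent on this oxygen; the single step between measured compounds concerns drawn configuration and does not bear on a methyl. For compound 4 in this assay a modest step toward a higher number is therefore expected, a 2.1-fold higher number from compound 2 to compound 4 (0.32 log units; beyond the scatter), with wide uncertainty. The estimate for compound 4 is 20 nM, ranging from 5 nM to 80 nM.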

Compound 4, half-maximal effective concentration: 41.7 nM
Compound 4: the middle estimate sits 2.1-fold (0.32 log units) below what was measured, and the stated range covers the measured number.
By their numbers in this assay, from the lowest: compounds 1 and 2 (each within the scatter of the next); then compounds 4 and 3 (each within the scatter of the next).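

In this assay, among the compounds shown here, replacing hydroxy with methoxy gives a 4.4-fold higher number from compound 2 to compound 4 (0.64 log units; beyond the scatter) on the E-drawn form, the first measured change to what this oxygen carries. The number therefore responds to methyl in place of hydrogen here, by a step beyond the scatter. Nothing available accounts for this step. On these data alone, whether an ethyl group or a longer chain on this oxygen would shift the number further remains open, as does whether the Z-drawn methoxy counterpart would differ from compound 4 as compound 3 differs from compound 2.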